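Allyl in place of ethyl on a dichlorophenyl sulfonamide

This account rests on a few compounds, and the source may have more. Where it says the series, first, only, none or still open, it means among the compounds named here.

Measured so far:
- compound 1 `CCN(c1ccccc1C)S(=O)(=O)c1cc(Cl)ccc1Cl` in an ADME assay on A549 cells (Homo sapiens) for cytotoxicity, read by MTT assay; on this read-out higher numbers stand for lower toxicity in this test and lower numbers for higher toxicity in this test: > 25000 nM
- compound 2 `C=CCN(c1ccccc1C)S(=O)(=O)c1cc(Cl)ccc1Cl` in this assay: > 5000 nM
- compound 3 `CCN(c1ccc(Cl)cc1C)S(=O)(=O)c1cc(Cl)ccc1Cl` in this assay: > 5000 nM

Each of these three numbers is a limit of this assay, not a measured value. Among the measured compounds shown here, compound 3 therefore stands only at a limit, and the same holds for the two other compounds, so no compound can be ranked against another here.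

Compound 4 `C=CCN(c1ccc(Cl)cc1C)S(=O)(=O)c1cc(Cl)ccc1Cl` has not been measured. It differs from compound 3 in one place: vinyl in place of methyl on a saturated chain carbon bound to a sulfonamide nitrogen.

For the measured compounds named here, the one measured step of the same kind runs from compound 1 to compound 2, and its size is a step that the two limits leave unreadable from compound 1 to compound 2. Both ends sit at limits, the one at the limit of > 25000 nM in this assay, at which 1 of the 3 values shown sits, and the other at the limit of > 5000 nM in this assay, at which 2 of the 3 values shown sit, so the step cannot be read. Likewise the step from compound 1 to compound 3 is a step that the two limits leave unreadable from compound 1 to compound 3, unreadable for the same reason.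

With no readable step to lean on, the expectation for compound 4 in this assay is simply that it stays near its limit, and the expected step that the limit leaves unreadable from compound 3 to compound 4 is none beyond the scatter. Compound 4 is thus estimated at 12000 nM, with a range from 4000 nM to 40000 nM.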

Compound 4, half-maximal cytotoxic concentration: > 5000 nM
Compound 4 gave a limit, no number; the forecaster's own chance of this, stated with the estimate: 80%; the middle value lies beyond the limit too.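

In this assay compound 4 gives > 5000 nM, which is a limit and not a number. Among the compounds shown here, its steps from compound 2 and from compound 3 therefore cannot be read, and no new step emerges. The compounds shown leave open whether allyl in place of ethyl, or chloro in place of hydrogen, changes the result in this assay at all.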